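Shortening the Alkyl Chain and the Tolerated Concentration

The compounds below may be only part of what the source reports. "The series", "measured", "known", "first", "only" and "open" are said of these compounds alone.

For the measured compounds named here, compound 3 `CCCCCCCCc1cc2cn(COCCO)c(O)nc-2n1` is the only member of this set for which a functional assay on HEL cells (Homo sapiens), read by microscopy (a higher number here means that more compound is tolerated, a lower number that less compound is tolerated), returns a number: in this assay compound 3 gives 80000 nM. The other two values are limits of the assay rather than numbers. Compound 1 `CCCCCCCc1cc2cn(COCCO)c(O)nc-2n1` gives only a limit, >= 400000 nM. Compound 2 `CCCCCCCCCc1cc2cn(COCCO)c(O)nc-2n1` likewise gives only a limit, > 80000 nM. Compound 4 `CCCCc1cc2cn(COCCO)c(O)nc-2n1` has not yet been measured; it differs from compound 3 by hydrogen in place of butyl on a saturated chain carbon, four bonds along the chain from an aromatic carbon.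

Among the measured pairs, the one readable step is an at least 5.0-fold lower number from compound 1 to compound 3 (0.69 log units; beyond the scatter). The other two, a step that the two limits leave unreadable from compound 1 to compound 2 and a number no higher from compound 2 to compound 3 (the limit leaves the size open), cannot be sized because of the limit of > 80000 nM in this assay, at which 1 of the 3 values shown sits, and (the limit of >= 400000 nM in this assay, at which 1 of the 3 values shown sits).

Adding a methyl to lengthen the chain thus lowered the number in this assay by a modest amount, and compound 4 moves in the opposite direction with a much larger cut of the chain. A higher number is therefore expected for compound 4, and quite possibly one that the assay can report only as a limit. Compound 4 is expected to give 400000 nM, with a range from 100000 nM to 1000000 nM. The expected step is a 5.0-fold higher number from compound 3 to compound 4 (0.70 log units; beyond the scatter).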

Compound 4, minimum cytotoxic concentration: > 400000 nM
Compound 4 ended at the assay's limit; the forecaster's own chance of this, stated with the estimate: 80%; the middle value sits exactly at the limit.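

Hydrogen in place of butyl on a saturated chain carbon, four bonds along the chain from an aromatic carbon, gives an at least 5.0-fold higher number from compound 3 to compound 4 (0.69 log units; beyond the scatter) in this assay, so the shorter chain of compound 4 falls on the same side of compound 3 as compound 1 does, and a second readable step now joins the earlier at least 5.0-fold lower number from compound 1 to compound 3 (0.69 log units; beyond the scatter). Compound 4 gives > 400000 nM, which is a limit of the assay and not a number. The steps that link compound 4 to compound 1 and to compound 2 cannot be read: the limit of > 400000 nM in this assay, at which 1 of the 4 values shown sits.

The compounds shown leave open how far the tolerated concentration of compound 4 really lies from that of compound 1, and so whether shortening the chain past that of compound 1 changes anything further in this assay. They also leave open what a longer chain than that of compound 2 would do, or a chain of similar length ending in an amine or a carboxylic acid in place of the terminal methyl.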